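Replacing Ethynyl with Furan-2-yl on the Shared Core

A few compounds are considered here, and "the series" means these few. Any claim that something is new, unique, unknown or untested is made for them only; others in the source may bear on it.

Measured so far:
- Compound 1 `C#Cc1cn([C@@H]2O[C@H](CO)[C@@H](O)[C@H]2O)c2ncnc(N(C)C)c12`: 290 nM
- Compound 2 `C#Cc1cn([C@@H]2O[C@H](CO)[C@@H](O)[C@H]2O)c2ncnc(OC)c12`: 190 nM

In a functional assay on HL-60 cells (Homo sapiens) for antiproliferative activity, read by XTT assay, with a stated time of 72 h (a higher number here means a weaker inhibitor, a lower number a stronger inhibitor), compound 1 gives 290 nM and compound 2 gives 190 nM. The two differ in one place, methoxy in place of dimethylamino on an aromatic carbon, and the step is a 1.5-fold lower number from compound 1 to compound 2 (0.18 log units; within the scatter), so the two values cannot be told apart. Compound 2 stands with the lowest of the two numbers, but only within the scatter of compound 1.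

Compound 3 `COc1ncnc2c1c(-c1ccco1)cn2[C@@H]1O[C@H](CO)[C@@H](O)[C@H]1O` keeps the methoxy of compound 2 and changes the other group: furan-2-yl in place of ethynyl on an aromatic carbon. For the measured compounds named here, no measured step touches this group; the only step recorded concerns the methoxy and dimethylamino exchange, and it was within the scatter. There is therefore no measured basis for predicting a direction, and the expected step in this assay is none beyond the scatter, with a wide range to reflect the lack of guidance. The step estimated for compound 3 is no change at the digits printed from compound 2 to compound 3 (within the scatter). Compound 3 is expected to give about 190 nM, in an estimated range from 50 nM to 700 nM.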

Compound 3, half-maximal inhibitory concentration: 100 nM
For compound 3 the middle estimate is 1.9-fold (0.28 log units) above the measured one; low and high end bracket the measured number.
By their numbers in this assay, from the lowest: compounds 3, 2 and 1 (each within the scatter of the next, the first and the last beyond it).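

In this assay, the exchange of ethynyl for furan-2-yl on the shared core gives a 1.9-fold lower number from compound 2 to compound 3 (0.28 log units; within the scatter), so the two compounds cannot be told apart. For the compounds shown here, this is the first measured step at this position, an aromatic carbon two ring bonds from the ring nitrogen, and it shows that a triple bond can give way to a five-membered aromatic ring carrying a hydrogen-bond acceptor without a change that stands clear of the scatter, so this position accepts at least one group quite different from ethynyl. The data offer no measured property or other evidence that would explain this result.

It remains open whether a phenyl ring, a thiophen-2-yl ring, an amine or a longer chain such as propyl at this position would give a number within the scatter of these compounds or one clearly apart from them. It is also open whether furan-2-yl would behave in the same way with dimethylamino in place of methoxy, since the step shown here was read with methoxy held fixed.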